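The source may report more compounds than this note shows. Statements on the series, on what has been measured and on what is new or still open speak of the compounds shown alone.

Compound 2, with structure `Nc1scc(CN2CCN(c3ccccc3C(F)(F)F)CC2)c1C(=O)c1ccc(Cl)cc1`, was tested in an assay on CHO cells for displacement of a labelled ligand from adenosine receptor A3 (Homo sapiens), read by scintillation counting, with a stated time of 120 min, tested at 10 uM (a higher number here means more inhibition at the concentration tested (going by the name of the read-out), a lower number less inhibition), where compound 2 gives 0%. That puts compound 2 level with compound 1, whose structure is `Nc1scc(CN2CCN(c3ccc(F)cc3Cl)CC2)c1C(=O)c1ccc(Cl)cc1` and which in this assay gives 0%; together the two are the lowest of the three numbers measured. Compound 3, with structure `Nc1scc(CN2CCN(c3cccc(F)c3)CC2)c1C(=O)c1ccc(Cl)cc1`, gives 4% in this assay, so all three aryl groups on the ring amine nitrogen leave the read-out close to zero.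

The steps among the measured compounds are small: no change at the digits printed from compound 1 to compound 2 (within the scatter), a number 4 percentage points higher from compound 2 to compound 3 (within the scatter) and a number 4 percentage points higher from compound 1 to compound 3 (within the scatter). Compound 4, structure `Nc1scc(CN2CCN(c3ccc(F)c(Cl)c3)CC2)c1C(=O)c1ccc(Cl)cc1`, differs from compound 2 by 3-chloro-4-fluorophenyl in place of 2-(trifluoromethyl)phenyl on an amine nitrogen in a ring. Every step that bears on it, each one a swap of the aryl group on that same ring nitrogen, stayed within the scatter, so no change beyond the scatter is expected in this assay. For compound 4 the expected read-out is 2%, with a range from 0% to 12%. The step this estimate implies is a number 2 percentage points higher from compound 2 to compound 4 (within the scatter), expected to be no real change.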

Compound 4, a percentage reported as inhibition, at one concentration (the size of the read-out at that concentration, not a potency): 0%
Compound 4: middle estimate off by 2 percentage points, on the high side; the measured number falls inside the stated range.
By their numbers in this assay, from the lowest: compounds 1, 2, 4 and 3 (each within the scatter of the next).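

In this assay, the 3-chloro-4-fluorophenyl group on the amine nitrogen in a ring gives no change at the digits printed from compound 2 to compound 4 (within the scatter), a number 4 percentage points lower from compound 3 to compound 4 (within the scatter) and no change at the digits printed from compound 1 to compound 4 (within the scatter). For the compounds shown here, this adds a fourth aryl group to the series and extends the earlier finding: across all four groups at this position, including one that swaps 10 heavy atoms for 8, the read-out stays close to zero, with no compound going against this. Nothing available here accounts for this flat result.

As far as these compounds go, all four groups are phenyl rings bearing fluorine, with or without chlorine, so it remains open whether a phenyl ring carrying an amine or a carboxylic acid would shift the read-out. Also open, from the compounds shown here alone, is whether a longer chain on this nitrogen, or a change elsewhere on the shared core, would do so.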